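The compounds below may be only part of what the source reports. "The series", "measured", "known", "first", "only" and "open" are said of these compounds alone.

Compound 1 `Cc1ccccc1-c1nn(-c2ccc(F)cc2F)cc1CN1CCN(c2ccccc2)CC1` sits at the limit of the assay in an ADME assay on Huh-7 cells (Homo sapiens) for cytotoxicity (a higher number here means that more compound is tolerated, a lower number that less compound is tolerated), with > 20000 nM. Compound 2 `Cc1ccccc1CNc1nn(-c2ccc(F)cc2F)cc1CNCCN1CCN(C)CC1` likewise sits at the limit, with > 20000 nM. Compound 3 `CN1CCN(CCNCc2cn(-c3ccc([N+](=O)[O-])cc3)nc2-c2ccc(C(F)(F)F)cc2)CC1` gives a measured number, 3200 nM.

Compound 2 therefore stands at the limit of > 20000 nM in this assay, at which 2 of the 3 values shown sit, and nothing separates it from compound 1 on the numbers shown. Only compound 3 gives a value that is not a limit. Compound 4 `CN1CCN(CCNCc2cn(-c3ccc(F)cc3F)nc2-c2ccc(S(=O)(=O)N(C)C)cc2)CC1` differs from compound 2 in one place: 4-(dimethylsulfamoyl)phenyl in place of (2-methylbenzyl)amino on an aromatic carbon. Among the compounds with values here, no step between two measured compounds matches this change, so its size can only be judged against the spread of the three values shown. The change is expected to move compound 4 toward a somewhat lower tolerated concentration, as an at least 1.6-fold lower number from compound 2 to compound 4 (0.22 log units; that floor lies within the scatter), though a reading at the limit remains quite possible. Compound 4 is therefore estimated at 12000 nM in this assay, within a range from 3000 nM to 20000 nM.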

Compound 4, half-maximal cytotoxic concentration: > 20000 nM
Compound 4 gave a limit, no number; the forecaster's own chance of this, stated with the estimate: 45%; middle value at least 1.6-fold (0.22 log units) away from the limit.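

Compound 2 and compound 4 both give a limit and no number, so no step between them can be read in this assay: the limit of > 20000 nM in this assay, at which 3 of the 4 values shown sit.

The compounds shown leave open whether 4-(dimethylsulfamoyl)phenyl in place of (2-methylbenzyl)amino changes the tolerated concentration at all.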